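The compounds below may be only part of what the source reports. "The series", "measured", "known", "first", "only" and "open" are said of these compounds alone.

For the measured compounds named here, in a functional assay on PC-3 cells (Homo sapiens) for cytotoxicity, read by sulforhodamine B assay, with a stated time of 48 h (on this read-out lower numbers stand for stronger inhibition and higher numbers for weaker inhibition), compound 2 `C=CCOc1ccc(C)cc1C(=O)c1cccnc1` gives 98000 nM, the highest of the two numbers known here; the nearest is compound 1 `O=C(c1cccnc1)c1cc(F)ccc1O`, which in this assay gives 11800 nM, and the gap between the two lies beyond the scatter. Compound 3 `Cc1ccc(O)c(C(=O)c2cccnc2)c1` arises from compound 2 by the change (hydrogen in place of allyl on an oxygen on an aromatic ring). Going by the values given here, no measured pair tells the size of such a step. A step toward lower numbers, expected to be a 6.5-fold lower number from compound 2 to compound 3 (0.82 log units; beyond the scatter), seems plausible because compound 1 gives 11800 nM with a hydroxy group in place. Compound 3 is estimated at 15000 nM, within a range of 5000 nM to 50000 nM.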

Compound 3, half-maximal inhibitory concentration: 10000 nM
Compound 3: the middle estimate sits 1.5-fold (0.18 log units) above what was measured; the measured number falls inside the stated range.
By their numbers in this assay, from the lowest: compounds 3 and 1 (each within the scatter of the next); then compound 2.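

In this assay, the change from allyloxy to hydroxy on the aromatic ring now has a measured size (a 9.8-fold lower number from compound 2 to compound 3 (0.99 log units; beyond the scatter)), and it lies beyond the scatter. With the hydroxy group in place, methyl in place of fluoro on an aromatic carbon (a 1.2-fold lower number from compound 1 to compound 3 (0.07 log units; within the scatter)) stays within the scatter, so this exchange does not separate the two compounds in this assay. Nothing available here explains either step.

As far as these compounds go, whether methoxy or an amine in place of hydroxy would read like compound 3 or like compound 2 remains open. So does the effect of a carboxylic acid or a longer chain in place of methyl.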